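A few compounds are considered here, and "the series" means these few. Any claim that something is new, unique, unknown or untested is made for them only; others in the source may bear on it.

Among the compounds with values here, the two compounds measured so far share a long chain that links a substituted aromatic ring to a piperazine carrying a bicyclic aromatic group. Compound 1, `C[C@H](NCc1ccc(OCCCCCCN2CCN(c3cccc4c3ccn4Cc3cccc(Cl)c3)CC2)cc1)C(N)=O`, and compound 2, `C[C@H](NCc1ccc(OCCCCCN2CCN(c3cccc4c3ccn4S(=O)(=O)c3ccccc3)CC2)cc1)C(N)=O`, differ in the chain length and in the group on the bicyclic nitrogen. In an assay on BTI cells for inhibition of Amine oxidase [flavin-containing] B (Homo sapiens), read by fluorescence, with stated times of 30 min and 1 h, tested at 1 uM (a higher number here means more inhibition at the concentration tested (going by the name of the read-out), a lower number less inhibition), compound 1 gives 23%, while compound 2 gives 17%. These two numbers lie within the usual scatter of one another, so nothing can be said about which of the two inhibits more.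

Compound 3, `C#CCN(C)Cc1ccc(OCCCCCCN2CCN(c3cccc4c3ccn4Cc3cccc(Cl)c3)CC2)cc1`, keeps the whole of compound 1 except one end group. The change is methyl(propargyl)amino in place of (1-carbamoylethyl)amino on a saturated chain carbon bound to an aromatic carbon. Within the data shown here, no measured pair showing this kind of change exists here, so the size of the step cannot be read from the data. Still, a rise beyond the scatter is expected, and the step of a number 37 percentage points higher from compound 1 to compound 3 (beyond the scatter) is my estimate of it. Compound 3 is therefore expected to reach about 60%, with a plausible range from 25% to 90%.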

Compound 3, a percentage reported as inhibition, at one concentration (the size of the read-out at that concentration, not a potency): 32%
Compound 3: middle estimate off by 28 percentage points, on the high side, within the range that was stated.
By their numbers in this assay, from the lowest: compounds 2, 1 and 3 (each within the scatter of the next, the first and the last beyond it).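

Within the data shown here, the step from the end group of compound 1 to that of compound 3 is the first comparison here that differs in one place only, on a saturated chain carbon bound to an aromatic carbon. In this assay, methyl(propargyl)amino in place of (1-carbamoylethyl)amino gives a number 9 percentage points higher from compound 1 to compound 3 (within the scatter), so at this single concentration the two end groups cannot be told apart, even though they differ clearly on paper: (1-carbamoylethyl)amino has 2 hydrogen-bond donors and a defined stereocentre, while methyl(propargyl)amino has no hydrogen-bond donors and carries a triple bond. Nothing available here explains this result.

On these data alone, what a simple primary amine, a dimethylamino group or a carboxylic acid would give on the same carbon remains open, and so does whether any group there can lift the read-out clearly beyond that of compound 1. As far as these compounds go, it is equally open whether methyl(propargyl)amino would behave in the same way on the core of compound 2, or with a longer chain between the aromatic ring and the piperazine.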